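Trifluoromethyl to methyl exchange in an antiproliferative series

The source may report more compounds than this note shows. Statements on the series, on what has been measured and on what is new or still open speak of the compounds shown alone.

Measured so far in a functional assay on MKN-74 cells (Homo sapiens) for antiproliferative activity, with a stated time of 24 h; a higher number here means a weaker inhibitor, a lower number a stronger inhibitor:
compound 1, `NC(=O)c1c(NC(=O)c2ccc(C(F)(F)F)cc2)sc2c1CCN(Cc1ccc(Cl)cc1Cl)C2`, gives 10900 nM
compound 2, `Cc1ccc(C(=O)Nc2sc3c(c2C(N)=O)CCN(Cc2ccc(Cl)cc2Cl)C3)cc1`, gives 25500 nM
compound 3, `NC(=O)c1c(NC(=O)c2ccccc2Cl)sc2c1CCN(C(=S)Nc1ccccc1C(F)(F)F)C2`, gives 1870 nM

Compound 3 carries the lowest number of the three, and its nearest neighbour is compound 1, with compound 2 furthest away. The difference between the core of compound 3 and the core of compound 1 is not broken down here.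

Compound 4, `Cc1ccccc1NC(=S)N1CCc2c(sc(NC(=O)c3ccccc3Cl)c2C(N)=O)C1`, is not yet measured in this assay. It differs from compound 3 in one place: methyl in place of trifluoromethyl on an aromatic carbon. The same kind of change has already been made once, from compound 1 to compound 2: methyl in place of trifluoromethyl on an aromatic carbon. That step read a 2.3-fold higher number from compound 1 to compound 2 (0.37 log units; beyond the scatter). The two places are not the same word for word: in compound 1 the group sits para to a large group on the ring of a benzamide, while in compound 3 it sits ortho to a large group on the ring attached to the thiourea. The step is therefore the same kind of change, not the same change, and how far the result carries over is open.

Among the measured compounds shown here, compound 4 is expected to show a 2.1-fold higher number from compound 3 to compound 4 (0.33 log units; beyond the scatter), resting on the single earlier step of a 2.3-fold higher number from compound 1 to compound 2 (0.37 log units; beyond the scatter), with wide bounds because the surroundings differ. In this assay compound 4 is estimated at 4000 nM, between 1500 nM and 12000 nM.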

Compound 4, half-maximal inhibitory concentration: 11700 nM
The estimate for compound 4 lay 2.9-fold (0.47 log units) below the measured number, within the range that was stated.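

In this assay, methyl in place of trifluoromethyl on an aromatic carbon again raised the number, a 6.3-fold higher number from compound 3 to compound 4 (0.80 log units; beyond the scatter), and the size of this step did not match the earlier one: the same change on two cores in this assay, a 2.3-fold higher number (0.37 log units; beyond the scatter) from compound 1 to compound 2 and a 6.3-fold higher number (0.80 log units; beyond the scatter) from compound 3 to compound 4, 2.7-fold (0.43 log units) apart, beyond the scatter of two such steps

Both pairs therefore point the same way, but two pairs are too few to establish a rule for the series, and the size of the step measured on one core should not be carried to another as a fixed correction. The pairs do not show what sets the size, since the two steps differ both in the core and in the ring that carries the group and its surroundings, and neither factor is varied alone.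

Going by these compounds, it remains open whether a methoxy group or a single fluorine in the same place on the 2-(trifluoromethyl)phenyl ring of compound 3 would read closer to trifluoromethyl or to methyl. On these data alone, it also remains open whether a third core would give a step nearer the smaller or the larger of these two, and whether the direction would hold in a second cell line.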